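Oxime ether series in the maximal electroshock model

This account rests on a few compounds, and the source may have more. Where it says the series, first, only, none or still open, it means among the compounds named here.

Measured compounds:
compound 1 `O=[N+]([O-])c1ccc(Cn2cc(CO/N=C/c3c(-c4ccc(F)cc4)nc4ccc(Br)cn34)nn2)cc1` 100 mg/kg
compound 2 `C#CCO/N=C/c1c(-c2ccc(C)cc2)nc2c(C)cccn12` 40 mg/kg

In a functional assay on the whole organism (strain NMRI) with Mus musculus as the target, in the maximal electroshock model, with a stated time of 4 h (on this read-out lower numbers stand for an effect already at smaller amounts and higher numbers for an effect only at larger amounts of compound), compound 2 gives 40 mg/kg, the lowest of the two numbers; compound 1 gives 100 mg/kg, a higher number that lies beyond the scatter. Compound 3 `Cc1ccc(-c2nc3c(C)cccn3c2/C=N/O)cc1` differs from compound 2 by one change: hydrogen in place of propargyl on an oxygen. Among the measured compounds shown here, no measured pair shows this change, so the step is judged from the change alone. A modest rise in the number, roughly at the edge of the scatter, is expected; the estimated step of a 1.5-fold higher number from compound 2 to compound 3 (0.18 log units; within the scatter) reflects this. Compound 3 is expected to give 60 mg/kg, with a range from 25 mg/kg to 150 mg/kg.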

Compound 3, minimum effective dose: 40 mg/kg
Compound 3: middle estimate off by 1.5-fold (0.18 log units), on the high side; the measured number falls inside the stated range.
By their numbers in this assay, from the lowest: compounds 2 and 3 (each within the scatter of the next); then compound 1.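

Propargyloxy to hydroxy on the oxygen gives no change at the digits printed from compound 2 to compound 3 (within the scatter) in this assay. In this pair, the propargyl with its triple bond is therefore not needed for the read-out, and the free oxime of compound 3 reads level with the ether of compound 2. No supporting measurement bears on why the two read alike.

As far as these compounds go, whether a methyl, a longer alkyl chain or a chain carrying an amine on this oxygen reads the same stays open. Compound 1 differs from both in more than one place, so its oxygen substituent cannot be judged alone.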